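The compounds below may be only part of what the source reports. "The series", "measured", "known", "first", "only" and "open" are said of these compounds alone.

Compound 1, `CC1CCN(c2c(S(=O)(=O)c3ccc(C#N)cc3)cnc3cc(F)ccc23)CC1`: 83%
Compound 2, `COc1ccc(S(=O)(=O)c2cnc3ccc(C)cc3c2N2CCC(C)CC2)cc1Cl`: 93%

In an assay on isolated protein for displacement of a labelled ligand from metabotropic glutamate receptor 5 (Homo sapiens), with a stated time of 60 min, tested at 1 uM (a higher number here means more inhibition at the concentration tested (going by the name of the read-out), a lower number less inhibition), compound 1 gives 83%, the smaller of the two numbers at hand. Among the compounds with values here, compound 2 gives 93% in this assay, a number that lies within the scatter of the first, so the two compounds cannot be told apart on these data alone; they also differ in several places at once, and no single step links them.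

Compound 3, `CC1CCN(c2c(S(=O)(=O)c3ccccc3)cnc3cc(F)ccc23)CC1`, stands one change away from compound 1: hydrogen in place of cyano on an aromatic carbon. Within the data shown here, no pair of measured compounds shows what this change does, so the size of the step from compound 1 to compound 3 rests on the structures alone. A hydrogen in place of cyano on an aromatic carbon removes a hydrogen-bond acceptor and a triple bond, and such a loss is expected to lower the inhibition somewhat, most likely by more than the scatter, though a flat result cannot be ruled out. The expected step is a number 18 percentage points lower from compound 1 to compound 3 (beyond the scatter). Compound 3 is accordingly estimated at 65% in this assay, with a range from 38% to 88%.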

Compound 3, a percentage reported as inhibition, at one concentration (the size of the read-out at that concentration, not a potency): 87%
The estimate for compound 3 lay 22 percentage points below the measured number; the measured number falls inside the stated range.
By their numbers in this assay, from the lowest: compounds 1, 3 and 2 (each within the scatter of the next).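

Within the data shown here, the pair of compound 1 and compound 3 gives the first reading of a single change: in this assay, going from 4-cyanophenyl to phenyl, with hydrogen in place of cyano on the aromatic carbon para to a large group, is a number 4 percentage points higher from compound 1 to compound 3 (within the scatter). At this position and at the one concentration tested, the nitrile is therefore not needed for a high read-out on this core, since compound 3, which lacks it, cannot be told apart from compound 1. Nothing measured here accounts for this result.

Because the read-out is taken at one concentration and is not a potency, any difference in potency between compound 1 and compound 3 remains unresolved. As far as these compounds go, it also remains open how an amine, a carboxylic acid or a longer chain would fare at this same place on the ring, and whether hydrogen in place of cyano would give a similar step on a core carrying other groups elsewhere.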